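Series notes: aryl-amine tail variation, clearance in human microsomes

The source may hold more compounds than are shown below. What is called first, only, known or untested is meant among the compounds shown, and "the series" means these compounds.

Measured so far in an in vitro ADME assay on microsomes from liver (Homo sapiens) for pharmacokinetics; on this read-out lower numbers stand for slow clearance and higher numbers for fast clearance:
- compound 1, `CN(C)CCN1CCN(c2ccc(Cn3c(=O)[nH]c4c(N)nc(C(F)(F)F)cc43)cn2)CC1`: < 8 mL.min-1.g-1
- compound 2, `Nc1nc(C(F)(F)F)cc2c1[nH]c(=O)n2Cc1ccc(NCCN2CCCC2)nc1`: 8.5 mL.min-1.g-1
- compound 3, `CN(CCN1CCCCC1)c1ccc(Cn2c(=O)[nH]c3c(N)nc(C(F)(F)F)cc32)cn1`: 25 mL.min-1.g-1

The value of compound 1 is a limit of this assay, not a number (the limit of < 8 mL.min-1.g-1 in this assay, at which 1 of the 3 values shown sits). Among the two numbers, compound 2 holds the lower one; its nearest neighbour is compound 3, reached by a 2.9-fold higher number from compound 2 to compound 3 (0.47 log units; beyond the scatter). The step of an at least 1.0-fold higher number from compound 1 to compound 2 (0.02 log units; that floor lies within the scatter) sits within the scatter.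

Compound 4, `CN(C)CCNc1ccc(Cn2c(=O)[nH]c3c(N)nc(C(F)(F)F)cc32)cn1`, is not yet measured. It differs from compound 2 as dimethylamino in place of pyrrolidin-1-yl on a saturated chain carbon, two bonds along the chain from a nitrogen on an aromatic ring.

For the measured compounds named here, no measured step swaps the same two groups. The step from compound 2 to compound 3 changes both the cyclic amine and the substitution on the aromatic nitrogen, so it bears only loosely; the step from compound 1 to compound 2 shows that a related tail exchange stayed within the scatter. Compound 1, which carries a dimethylamino on its chain, sits at the limit. The expectation for compound 4 is therefore no change beyond the scatter, or a slightly lower number, as a 1.2-fold lower number from compound 2 to compound 4 (0.08 log units; within the scatter). Compound 4 is estimated at 7 mL.min-1.g-1 in this assay, with a range from 3 mL.min-1.g-1 to 15 mL.min-1.g-1.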

Compound 4, intrinsic clearance in microsomes: 9 mL.min-1.g-1
Compound 4: middle estimate off by 1.3-fold (0.11 log units), on the low side, within the range that was stated.
By their numbers in this assay, from the lowest: compounds 2 and 4 (each within the scatter of the next); then compound 3. At a limit, below all of these: compound 1.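

Dimethylamino in place of pyrrolidin-1-yl on a saturated chain carbon, two bonds along the chain from a nitrogen on an aromatic ring, gives no separable difference in this assay, with a 1.1-fold higher number from compound 2 to compound 4 (0.02 log units; within the scatter), so at this place the ring in the tail is not needed to keep the number at this level. The higher number of compound 3 stays apart from this tail too, with a 2.8-fold lower number from compound 3 to compound 4 (0.44 log units; beyond the scatter), but that step exchanges the whole tail and cannot say whether the methyl on the nitrogen or the piperidin-1-yl carries the difference. Compound 1 stands at a limit, not a number: the limit of < 8 mL.min-1.g-1 in this assay, at which 1 of the 4 values shown sits. The step, with an at least 1.1-fold higher number from compound 1 to compound 4 (0.05 log units; that floor lies within the scatter), cannot be read.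

Still open is which part of the tail of compound 3 accounts for its step, a question that a tail with only one of those two features would settle. Also open, going by these compounds, is how this assay responds to a morpholin-4-yl at the chain end or to a longer chain between the two nitrogens.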